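Side chain changes on the chloro-bearing core: tail flick readout

A few compounds are considered here, and "the series" means these few. Any claim that something is new, unique, unknown or untested is made for them only; others in the source may bear on it.

Measured so far:
Compound 1 `O=C(CN(c1ncnc2c1ncn2C1CCCCO1)C1CC1)N[C@@H](CO)C(=O)OCc1ccccc1` gives 18.3% in a functional assay on the whole organism (Tail, strain ICR) with Mus musculus as the target, in the tail flick test, with a stated time of 150 min, at a dose of 25 umol/kg by the oral route; a lower number here means a weaker effect, a higher number a stronger effect of the compound at the dose given.
Compound 2 `N=C(N)NCCC[C@H](NC(=O)CN(c1nc(Cl)nc2[nH]cnc12)C1CC1)C(=O)OCc1ccccc1` gives 6.12% in this assay.
Compound 3 `O=C(CN(c1nc(Cl)nc2[nH]cnc12)C1CC1)N[C@@H](CC(=O)OCc1ccccc1)C(=O)OCc1ccccc1` gives 6.68% in this assay.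

Compound 3 stands second highest of the three numbers. Its nearest neighbour is compound 2, and the step from compound 2 to compound 3 was a number 0.6 percentage points higher from compound 2 to compound 3 (within the scatter), so the two cannot be ordered. Among the measured compounds shown here, compound 1, which carries a different core, sits furthest away; its value and that of compound 3 differ beyond the scatter, but no single-change step connects them.

The next compound, compound 4 `CC[C@H](C)[C@H](NC(=O)CN(c1nc(Cl)nc2[nH]cnc12)C1CC1)C(=O)OCc1ccccc1`, has not been measured in this assay. It differs from compound 3 in one place: sec-butyl in place of (benzyloxycarbonyl)methyl on a saturated chain carbon bound to an amide-type nitrogen and a carbonyl carbon.

For the measured compounds named here, the only measured step that bears on this change is the one from compound 2 to compound 3, which also swaps the side chain on the same chain carbon and moved the readout by a number 0.6 percentage points higher from compound 2 to compound 3 (within the scatter). On the chloro-bearing core, the two side chains seen so far gave readouts within the scatter of each other. The expectation is therefore a step of about a number 1.3 percentage points higher from compound 3 to compound 4 (within the scatter), not beyond the scatter, in either direction.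

The estimate for compound 4 is 8%, with a range from 0% to 20%.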

Compound 4, a percentage reported as activity, at one dose (the size of the read-out at that dose, not a potency): 6.9%
Compound 4: middle estimate off by 1.1 percentage points, on the high side, and the stated range covers the measured number.
By their numbers in this assay, from the lowest: compounds 2, 3 and 4 (each within the scatter of the next); then compound 1.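

In this assay, the new side chain on the shared core gives a number 0.2 percentage points higher from compound 3 to compound 4 (within the scatter), and against the side chain of compound 2 it gives a number 0.8 percentage points higher from compound 2 to compound 4 (within the scatter), so three different groups on a saturated chain carbon bound to an amide-type nitrogen and a carbonyl carbon now cannot be told apart. The change to sec-butyl drops the six-membered aromatic ring and the 2 hydrogen-bond acceptors of (benzyloxycarbonyl)methyl and goes from 11 heavy atoms to 4, yet the readout stays within the scatter, so on this core, at this dose, neither that ring nor those acceptors separates the compounds. Nothing available on these compounds offers an account of why the three readouts coincide.

As far as these compounds go, it remains open whether any group at this carbon can move the readout on the shared core beyond the scatter, for instance a free carboxylic acid or a primary amine on a short chain. Compound 1, at 18.3%, differs from the others in more than one place, so its value cannot be assigned to its side chain or to its core.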